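Pentyloxy on the fused ring of compound 1: expected lipophilicity

The compounds below may be only part of what the source reports. "The series", "measured", "known", "first", "only" and "open" are said of these compounds alone.

Compound 1 `COc1ccc(-c2[nH]c3ccccc3c2C2=C(Br)C(=O)NC2=O)cc1` has the lowest number of the three measured compounds in a physicochemical assay for lipophilicity (on this read-out higher numbers stand for higher lipophilicity and lower numbers for lower lipophilicity), giving 2.42. Compound 2 `O=C1NC(=O)C(c2c(-c3ccc(OCc4ccccc4)cc3)[nH]c3ccccc23)=C1Br` gives 3.3 and compound 3 `O=C1NC(=O)C(c2c(-c3ccc(OCc4cccc5ccccc45)cc3)[nH]c3ccccc23)=C1Br` gives 3.76 in this assay. Compound 4 `CCCCCOc1ccc2[nH]c(-c3ccc(OC)cc3)c(C3=C(Br)C(=O)NC3=O)c2c1` differs from compound 1 by pentyloxy in place of hydrogen on an aromatic carbon. Going by the values given here, no measured step matches this change; the closest guides are a number 0.88 log units higher from compound 1 to compound 2 (beyond the scatter) and a number 1.34 log units higher from compound 1 to compound 3 (beyond the scatter), where a ring of carbon atoms entered in place of hydrogen elsewhere on the shared core, and a number 0.46 log units higher from compound 2 to compound 3 (beyond the scatter). Because a number 0.88 log units higher from compound 1 to compound 2 (beyond the scatter) and a number 1.34 log units higher from compound 1 to compound 3 (beyond the scatter) both rose beyond the scatter, a rise of comparable size is expected here. The step of a number 1.08 log units higher from compound 1 to compound 4 (beyond the scatter) is the estimate. Compound 4 is therefore expected to reach 3.5, within 2.9 to 4.2.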

Compound 4, partition coefficient: 3.77
Beside the measured number, compound 4's estimate is 0.27 log units below it; low and high end bracket the measured number.
By their numbers in this assay, from the lowest: compound 1; then compound 2; then compounds 3 and 4 (each within the scatter of the next).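

In this assay, pentyloxy in place of hydrogen on an aromatic carbon of the fused system gives a number 1.35 log units higher from compound 1 to compound 4 (beyond the scatter). Going by these compounds alone, the earlier steps changed only the group on the oxygen of the methoxy-bearing ring, so this is the first sign that the number also moves with a change on the fused ring, and with an entering group that has no ring. Nothing available here explains the size of this rise.

From the compounds shown here alone, how a shorter chain such as ethoxy, an amine or a carboxylic acid at this carbon would shift the number remains open. So does whether pentyloxy would do the same on other carbons of that ring.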